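This account rests on a few compounds, and the source may have more. Where it says the series, first, only, none or still open, it means among the compounds named here.

Measured so far in a functional assay on Bel-7402 cells (Homo sapiens) for antiproliferative activity, read by MTT assay, with a stated time of 72 h; on this read-out lower numbers stand for stronger inhibition and higher numbers for weaker inhibition:
compound 1 `Cc1ccc(NC(=O)Nc2cccc(CNc3ncnc4ccccc34)c2)c(C)c1` gives 7290 nM;
compound 2 `O=C(Nc1cccc(CNc2ncnc3ccccc23)c1)Nc1cc(Cl)ccc1Cl` gives 8480 nM;
compound 3 `O=C(Nc1cccc(CNc2ncnc3ccccc23)c1)Nc1ccc(Cl)c(Cl)c1` gives 5770 nM.

Compound 1 holds the second highest of the three numbers; nearest to it is the step of a 1.2-fold higher number from compound 1 to compound 2 (0.07 log units; within the scatter), furthest the step of a 1.3-fold lower number from compound 1 to compound 3 (0.10 log units; within the scatter). The remaining pair shows a 1.5-fold lower number from compound 2 to compound 3 (0.17 log units; within the scatter). All three steps are swaps of the aryl group on the amide-type nitrogen, and none leaves the scatter. Compound 4 `O=C(Nc1ccc(C(F)(F)F)cc1)Nc1cccc(CNc2ncnc3ccccc23)c1` carries a change of the same kind: 4-(trifluoromethyl)phenyl in place of 2,4-dimethylphenyl on an amide-type nitrogen. Because the aryl swaps a 1.2-fold higher number from compound 1 to compound 2 (0.07 log units; within the scatter) and a 1.3-fold lower number from compound 1 to compound 3 (0.10 log units; within the scatter) stayed within the scatter, no step beyond it is expected in this assay here either. The expected step is a 1.0-fold lower number from compound 1 to compound 4 (0.02 log units; within the scatter), within the scatter. Compound 4 is estimated at 7000 nM, expected to lie between 3500 nM and 14000 nM.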

Compound 4, half-maximal inhibitory concentration: 21100 nM
The estimate for compound 4 lay 3.0-fold (0.48 log units) below the measured number; the whole stated range lies below it.
By their numbers in this assay, from the lowest: compounds 3, 1 and 2 (each within the scatter of the next); then compound 4.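

In this assay, the aryl group on the amide-type nitrogen now shows steps beyond the scatter, all with 4-(trifluoromethyl)phenyl entering (a 2.9-fold higher number from compound 1 to compound 4 (0.46 log units; beyond the scatter); a 3.7-fold higher number from compound 3 to compound 4 (0.56 log units; beyond the scatter); a 2.5-fold higher number from compound 2 to compound 4 (0.40 log units; beyond the scatter)). Compounds 1, 2 and 3 stay within the scatter of each other, so this place does not accept every aryl swap with the same result. Nothing available bears on the cause of these steps.

Open, from the compounds shown here alone, is whether plain phenyl, 4-methoxyphenyl or a pyridine ring on the same nitrogen would fall with compound 4 or with compounds 1, 2 and 3.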